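The source may report more compounds than this note shows. Statements on the series, on what has been measured and on what is new or still open speak of the compounds shown alone.

Three ureas built on the same core have been measured, and a fourth awaits its number. Compound 1 `O=C(NC1CCN(Cc2ccn(-c3ccc(C(F)(F)F)cc3)c2)CC1)N1CCCC1Cc1cccnc1` gives 26 nM in an assay on HEK293 cells for displacement of a labelled ligand from melanin-concentrating hormone receptor 1 (Homo sapiens) (a higher number here means a weaker inhibitor, a lower number a stronger inhibitor), compound 3 `O=C(NC1CCN(Cc2ccn(-c3ccc(C(F)(F)F)cc3)c2)CC1)N1CCn2cccc2C1c1ccccc1` gives 10 nM, and compound 2 `O=C(O)CC(NC(=O)NC1CCN(Cc2ccn(-c3ccc(C(F)(F)F)cc3)c2)CC1)c1ccccc1` gives 412 nM. Compound 2 therefore stands highest of the three, with compound 1 nearest and compound 3 furthest from it. Among the compounds with values here, the one step that reaches compound 2 is a 16-fold higher number from compound 1 to compound 2 (1.20 log units; beyond the scatter), a large move that replaced a pyrrolidine-based group with an open-chain amine on the urea carbonyl.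

The unmeasured compound 4 `O=C(NC1CCN(Cc2ccn(-c3ccc(C(F)(F)F)cc3)c2)CC1)N1CC[C@H](O)C1` reverses that kind of change: 3-hydroxypyrrolidin-1-yl in place of (2-carboxy-1-phenylethyl)amino on a carbonyl carbon. Within the data shown here, because the single relevant step, a 16-fold higher number from compound 1 to compound 2 (1.20 log units; beyond the scatter), was large and ran toward higher numbers when the ring was opened, closing it again is expected to bring the number down, though the new ring lacks the aromatic group of compound 1, so the return is expected to be only partial, a 3.4-fold lower number from compound 2 to compound 4 (0.54 log units; beyond the scatter). Compound 4 is estimated at 120 nM, within 30 nM to 500 nM.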

Compound 4, half-maximal inhibitory concentration: 125 nM
Beside the measured number, compound 4's estimate is 1.0-fold (0.02 log units) below it; the range from low to high includes it.
By their numbers in this assay, from the lowest: compound 3; then compound 1; then compound 4; then compound 2.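

In this assay, the position on the carbonyl carbon needs no aromatic ring for a number lower than that of compound 2: putting 3-hydroxypyrrolidin-1-yl in place of (2-carboxy-1-phenylethyl)amino gives a 3.3-fold lower number from compound 2 to compound 4 (0.52 log units; beyond the scatter). A pyrrolidine on this carbonyl is not enough by itself to reach the number of compound 1, however, as 3-hydroxypyrrolidin-1-yl in place of 2-((pyridin-3-yl)methyl)pyrrolidin-1-yl gives a 4.8-fold higher number from compound 1 to compound 4 (0.68 log units; beyond the scatter). No measurement available here accounts for either shift.

The compounds shown leave open what the hydroxy group contributes, which a plain pyrrolidin-1-yl on this carbonyl would show, and whether the opposite stereoisomer behaves alike. They also leave open whether the carboxylic acid or the phenyl ring sets the number of compound 2, which a (1-phenylethyl)amino group would help separate.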